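Iodo in Place of Trifluoromethoxy in a Cytotoxicity Screen

This account rests on a few compounds, and the source may have more. Where it says the series, first, only, none or still open, it means among the compounds named here.

compound 1 `C/C(=N\NC(=O)c1ccncc1)C(=O)Nc1ccc(OC(F)(F)F)cc1` — > 50000 nM
compound 2 `C/C(=N\NC(=O)c1ccncc1)C(=O)Nc1ccc(Cl)c(Cl)c1` — > 50000 nM

In an ADME assay on HepG2 cells (Homo sapiens) for cytotoxicity, read by MTT assay (a lower number here means a stronger inhibitor, a higher number a weaker inhibitor), compound 1 gives > 50000 nM, which is a limit of the assay and not a number. Compound 2 likewise gives > 50000 nM in this assay, again a limit. So compound 1 stands on no measured number at all: both values shown sit at the limit of > 50000 nM in this assay, at which 2 of the 2 values shown sit, and no step between measured compounds can be stated.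

Compound 3 `C/C(=N\NC(=O)c1ccncc1)C(=O)Nc1ccc(I)cc1` differs from compound 1 by iodo in place of trifluoromethoxy on an aromatic carbon. With nothing but two limits to go on, no step beyond the scatter is expected in this assay, and the most likely outcome for compound 3 is another limit. Should a number appear, compound 3 is estimated at 60000 nM, in the range 20000 nM to 200000 nM. That estimate means a step from compound 1 to compound 3 of a step that the limit leaves unreadable from compound 1 to compound 3, within the usual scatter.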

Compound 3, half-maximal inhibitory concentration: > 50000 nM
Compound 3: no number, only a limit (the forecaster's own chance of this, stated with the estimate: 80%); the middle value lies beyond the limit too.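

In this assay compound 3 gives > 50000 nM, again a limit of the assay and not a number, so no step between compound 1 and compound 3 can be read: the limit of > 50000 nM in this assay, at which 3 of the 3 values shown sit.

The compounds shown leave open whether any change on the shared core would give a readable number in this assay.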